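Swapping a carbamoyl for a methylsulfanylmethyl side chain

This account rests on a few compounds, and the source may have more. Where it says the series, first, only, none or still open, it means among the compounds named here.

Of the compounds shown here, three have been tested in a functional assay on the whole organism (Tail, strain ICR) with Mus musculus as the target, in the tail flick test, with a stated time of 120 min, at a dose of 25 umol/kg by the oral route; on this read-out higher numbers stand for a stronger effect at the one dose given and lower numbers for a weaker effect. Compound 1 `O=C(CN(c1nc(Cl)nc2[nH]cnc12)C1CC1)N[C@@H](CC(=O)OCc1ccccc1)C(=O)OCc1ccccc1` gives 12.1%, compound 2 `CC[C@H](C)[C@H](NC(=O)CN(c1ncnc2c1ncn2C1CCCCO1)C1CC1)C(=O)OCc1ccccc1` gives 20.4%, and compound 3 `NC(=O)C[C@H](NC(=O)CN(c1nc(Cl)nc2[nH]cnc12)C1CC1)C(=O)O` gives 17%. Compound 3 stands second highest of the three numbers, yet its gaps to compound 2 and to compound 1 both lie within the usual scatter, so the three cannot be told apart. Compound 4 `CSCC[C@H](NC(=O)CN(c1nc(Cl)nc2[nH]cnc12)C1CC1)C(=O)O` has not yet been measured. It differs from compound 3 in one place: (methylsulfanyl)methyl in place of carbamoyl on a saturated chain carbon, two bonds along the chain from an amide-type nitrogen and a carbonyl carbon. For the measured compounds named here, no measured pair covers a change of this kind, so a step beyond the scatter is not expected in either direction. In this assay compound 4 is expected to give about 17%, within a range of 5% to 30%. The expected step is no change at the digits printed from compound 3 to compound 4 (within the scatter).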

Compound 4, a percentage reported as activity, at one dose (the size of the read-out at that dose, not a potency): 5.67%
Compound 4: middle estimate off by 11.3 percentage points, on the high side; the range from low to high includes it.
By their numbers in this assay, from the lowest: compounds 4, 1, 3 and 2 (each within the scatter of the next, the first and the last beyond it).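

For the compounds shown here, this is the first change measured at this position, and it shows that the side chain on this saturated chain carbon is not neutral in this assay: (methylsulfanyl)methyl in place of carbamoyl gives a number 11.3 percentage points lower from compound 3 to compound 4 (beyond the scatter) for this one pair. Nothing measured here accounts for that step.

As far as these compounds go, what an amine or a plain methyl group at this place would give stays open. So does whether the step comes from removing carbamoyl or from adding (methylsulfanyl)methyl.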